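Swapping the benzylidene aryl group in a semicarbazone series

The compounds below may be only part of what the source reports. "The series", "measured", "known", "first", "only" and "open" are said of these compounds alone.

Going by the values given here, compound 2 `CN(C)CCn1cnnc1-c1cc(Oc2ccc(NC(=O)N/N=C/c3ccc(F)cc3Cl)cc2F)ccn1` gives 1120 nM in a functional assay on A549 cells (Homo sapiens) for cytotoxicity, read by MTT assay, with a stated time of 72 h (on this read-out lower numbers stand for stronger inhibition and higher numbers for weaker inhibition), the lowest of the two numbers so far, while compound 1 `CN(C)CCn1cnnc1-c1cc(Oc2ccc(NC(=O)N/N=C/c3ccccc3)cc2F)ccn1` gives 1860 nM in this assay; the step of a 1.7-fold lower number from compound 1 to compound 2 (0.22 log units; within the scatter) is within the scatter. Compound 3 `Cc1cc(/C=N/NC(=O)Nc2ccc(Oc3ccnc(-c4nncn4CCN(C)C)c3)c(F)c2)cc(C)c1O` has not yet been measured. It differs from compound 2 by 4-hydroxy-3,5-dimethylphenyl in place of 2-chloro-4-fluorophenyl on a carbon with a double bond to nitrogen. The only measured step that touches this position is the one from compound 1 to compound 2, which was within the scatter, so there is no shown evidence that the aryl group on the carbon with a double bond to nitrogen moves the number much. The expected step of a 1.0-fold lower number from compound 2 to compound 3 (0.01 log units; within the scatter) is therefore small, with no clear direction beyond the scatter. Compound 3 is estimated to give 1100 nM in this assay, in a range from 350 nM to 3500 nM.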

Compound 3, half-maximal inhibitory concentration: 1640 nM
Compound 3: middle estimate off by 1.5-fold (0.17 log units), on the low side, and the stated range covers the measured number.
By their numbers in this assay, from the lowest: compounds 2, 3 and 1 (each within the scatter of the next).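

In this assay, a third aryl group on the carbon with a double bond to nitrogen again stays within the scatter: a 1.5-fold higher number from compound 2 to compound 3 (0.17 log units; within the scatter), and a 1.1-fold lower number from compound 1 to compound 3 (0.05 log units; within the scatter). So 4-hydroxy-3,5-dimethylphenyl, which carries a hydrogen-bond donor and a hydrogen-bond acceptor where 2-chloro-4-fluorophenyl has neither and which holds no halogen, gives no step beyond the scatter from either phenyl or 2-chloro-4-fluorophenyl at this position. Nothing available explains why these three groups read so alike.

As far as these compounds go, whether an aryl group of another kind at this place, such as 4-carboxyphenyl or 4-(dimethylamino)phenyl, would give a step beyond the scatter remains open. From the compounds shown here alone, it is also open whether the same holds when the shared core is changed elsewhere, since all three compounds carry it unchanged.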